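The source may hold more compounds than are shown below. What is called first, only, known or untested is meant among the compounds shown, and "the series" means these compounds.

Of the compounds shown here, two have been measured in an ADME assay on MRC5 cells (Homo sapiens) for inhibition, with a stated time of 72 h; a higher number here means that more compound is needed for the effect, a lower number that less compound is needed. Compound 1 `COc1cccc(OC)c1C(=O)Nc1c[nH]nc1C(=O)N[C@H]1CC[C@H](O)CC1` gives 34000 nM there, the highest of the two numbers recorded. Compound 2 `CO[C@H]1CC[C@H](NC(=O)c2n[nH]cc2NC(=O)c2ccccc2C(F)(F)F)CC1` gives 3300 nM in this assay, a lower number by a margin that lies beyond the usual scatter; compound 2 also differs from compound 1 in more than one place, so this gap cannot be tied to any single change.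

Compound 3 `COc1cccc(OC)c1C(=O)Nc1c[nH]nc1C(=O)N[C@H]1CC[C@H](OC)CC1` has not yet been measured. It differs from compound 1 in one place only: methyl in place of hydrogen on an oxygen on a saturated carbon. Going by the values given here, no measured pair shows this change by itself, so the numbers at hand do not tell how large its effect is. Compound 2 happens to carry the methoxy on its ring as well, but it is an imperfect pointer, since the rest of its structure differs too.

A modest shift toward a lower number is expected, estimated as a 2.3-fold lower number from compound 1 to compound 3 (0.36 log units; beyond the scatter). For compound 3 the expected value in this assay is 15000 nM, most likely falling between 5000 nM and 40000 nM.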

Compound 3, half-maximal effective concentration: 31000 nM
Compound 3: middle estimate off by 2.1-fold (0.32 log units), on the low side, within the range that was stated.
By their numbers in this assay, from the lowest: compound 2; then compounds 3 and 1 (each within the scatter of the next).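

Going by these compounds alone, putting methyl on the oxygen, which turns the 4-hydroxycyclohexyl group into 4-methoxycyclohexyl, gives the first clean reading of this position in this assay, and it comes to a 1.1-fold lower number from compound 1 to compound 3 (0.04 log units; within the scatter), so on this core the two groups cannot be told apart in this read-out. Compound 3 carries the same 4-methoxycyclohexyl group as compound 2, yet compound 3 gives 31000 nM and compound 2 gives 3300 nM, so the methoxy alone does not account for the value of compound 2. Nothing at hand offers an explanation for why this swap makes so little difference.

Open still is whether this position tolerates anything else, for instance an amine or a carboxylic acid in place of the hydroxy, or a longer chain such as ethoxy on the oxygen. From the compounds shown here alone, it is also open whether hydroxy and methoxy would read alike on the core of compound 2, where the numbers sit in a lower range.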